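A ring swap at one carbon, leading to compound 4

A few compounds are considered here, and "the series" means these few. Any claim that something is new, unique, unknown or untested is made for them only; others in the source may bear on it.

Of the compounds shown here, three sharing one core have been tested in a functional assay on MCF7 cells (Homo sapiens) for antiproliferative activity, read by CellTiter-Glo, with a stated time of 5 days; a higher number here means a weaker inhibitor, a lower number a stronger inhibitor. Compound 1 `CC/C(=C(/c1ccc(/C=C/C(=O)O)cc1)c1ccn2nncc2c1)c1ccccc1` gives > 500 nM, which is a limit of the assay and not a number. Compound 2 `CC/C(=C(/c1ccc(/C=C/C(=O)O)cc1)c1ccc(-c2nccs2)cc1)c1ccccc1` gives 290 nM, while compound 3 `CC/C(=C(/c1ccc(/C=C/C(=O)O)cc1)c1ccc(-c2cn[nH]c2)cc1)c1ccccc1` gives 40 nM, the lower of the two actual numbers.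

Compound 4 `CC/C(=C(/c1ccc(/C=C/C(=O)O)cc1)c1ccc(N2CCN(C)CC2)cc1)c1ccccc1` changes compound 3 at a single place: 4-methylpiperazin-1-yl in place of 1H-pyrazol-4-yl on an aromatic carbon. This puts 4-methylpiperazin-1-yl in place of 1H-pyrazol-4-yl on an aromatic carbon, para to a large group.

Going by the values given here, one measured step bears on this change. Putting 1H-pyrazol-4-yl in place of 1,3-thiazol-2-yl at that same kind of carbon gave a 7.3-fold lower number from compound 2 to compound 3 (0.86 log units; beyond the scatter), a modest step beyond the scatter. Among the compounds with values here, this place therefore responds to the group it carries, and the group in compound 3 is the one with the lowest number so far. A step of similar size in the opposite direction seems likely, and the expected change is a 3.8-fold higher number from compound 3 to compound 4 (0.57 log units; beyond the scatter). For compound 4 the estimated value is 150 nM, with an expected range of 45 nM to 500 nM.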

Compound 4, half-maximal inhibitory concentration: 220 nM
Compound 4: the middle estimate sits 1.5-fold (0.17 log units) below what was measured, within the range that was stated.
By their numbers in this assay, from the lowest: compound 3; then compounds 4 and 2 (each within the scatter of the next). At a limit, above all of these: compound 1.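

Replacing the 1H-pyrazol-4-yl group of compound 3 with 4-methylpiperazin-1-yl, a six-membered non-aromatic ring, gives a 5.5-fold higher number from compound 3 to compound 4 (0.74 log units; beyond the scatter), so this carbon can carry a non-aromatic ring, but the number rises. Replacing the 1,3-thiazol-2-yl group gives a 1.3-fold lower number from compound 2 to compound 4 (0.12 log units; within the scatter), so these two quite different rings cannot be told apart here, and only the 1H-pyrazol-4-yl group stands clear of both. The 1H-pyrazol-4-yl group carries a hydrogen-bond donor and 4-methylpiperazin-1-yl carries none, but nothing measured here ties that or any other difference to the numbers.

Going by these compounds, it remains open whether the ring itself or its methyl group sets the value of compound 4, a question that a piperazin-1-yl or morpholin-4-yl group could address. A 1-methylpyrazol-4-yl group could show whether the ring hydrogen on nitrogen in compound 3 matters.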